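The source may hold more compounds than are shown below. What is called first, only, known or untested is meant among the compounds shown, and "the series" means these compounds.

Compound 1 `CN(C)/C(=N/CCCCn1nc(-c2ccccc2)ccc1=O)NC#N`: 30.3 mg/kg
Compound 2 `CC(C)(C)/N=C(\S)NCCCCn1nc(-c2ccccc2)ccc1=O`: > 100 mg/kg (a limit of the assay)
Compound 3 `N/C(S)=N/CCCCn1nc(-c2ccccc2)ccc1=O`: 36.3 mg/kg

In a functional assay on the whole organism (stomach) with Rattus norvegicus as the target (a higher number here means that more compound is needed for the effect, a lower number that less compound is needed), compound 3 gives 36.3 mg/kg, the highest of the two numbers shown. Compound 1 gives 30.3 mg/kg, and the step is a 1.2-fold higher number from compound 1 to compound 3 (0.08 log units; within the scatter), so the two sit together. Compound 2 gives only a limit of the assay, > 100 mg/kg (the limit of > 100 mg/kg in this assay, at which 1 of the 3 values shown sits).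

Compound 4 `C/N=C(\S)NCCCn1nc(-c2ccccc2)ccc1=O` is not yet measured. It differs from compound 3 by a group of 5 heavy atoms (2 carbon, 2 nitrogen, 1 sulfur; no ring) in place of a group of 5 heavy atoms (2 carbon, 2 nitrogen, 1 sulfur; no ring), on a saturated chain carbon, three bonds along the chain from an aromatic nitrogen. Among the measured compounds shown here, no measured step repeats this change. For the measured compounds named here, the steps that bear on it are an at least 2.7-fold lower number from compound 2 to compound 3 (0.44 log units; beyond the scatter) and an at least 3.3-fold higher number from compound 1 to compound 2 (0.51 log units; beyond the scatter), both exchanges of the group on the saturated chain carbon, and the exchange leading to compound 2 carried the number past the limit. The change to compound 4 is smaller in kind, and an increase of modest size at most is expected: a 1.2-fold higher number from compound 3 to compound 4 (0.09 log units; within the scatter). Compound 4 is therefore estimated to give 45 mg/kg in this assay, with a range from 20 mg/kg to 100 mg/kg.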

Compound 4, dose for half-maximal effect: > 100 mg/kg
Compound 4 gave a limit, no number; the forecaster's own chance of this, stated with the estimate: 20%; middle value at least 2.2-fold (0.34 log units) from the limit.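

The exchange at this place, on a saturated chain carbon, three bonds along the chain from an aromatic nitrogen, keeps the heavy atoms, double bond and hydrogen-bond donor and acceptor counts unchanged, yet in this assay it gives an at least 2.7-fold higher number from compound 3 to compound 4 (0.44 log units; beyond the scatter). The earlier step to the same ceiling, an at least 3.3-fold higher number from compound 1 to compound 2 (0.51 log units; beyond the scatter), brought a different group of the same heavy-atom count, so these counts do not track the read-out across compound 1, compound 2, compound 3 and compound 4. Compound 4 gives only a limit of the assay, and the ceiling now holds a second compound: the limit of > 100 mg/kg in this assay, at which 2 of the 4 values shown sit.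

Going by these compounds, since the value of compound 4 is a limit, the true size of the step stays unknown, and the rearranged atoms are not separated into individual contributions. On these data alone, how a longer chain or a simple amine at this place would read also remains open.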